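The source may report more compounds than this note shows. Statements on the series, on what has been measured and on what is new or still open speak of the compounds shown alone.

Measured compounds in the series:

- compound 1 `COc1ccc(-c2ccc(-c3ccc(C(=N)N)cc3)s2)cc1`: 175 nM
- compound 2 `N=C(N)c1ccc(-c2ccc(-c3ccc(Cl)cc3)s2)cc1F`: 168 nM
- compound 3 `COc1cc(OC)cc(-c2ccc(-c3ccc(C(=N)N)c(F)c3)s2)c1`: 194 nM

All three have been run in a functional assay on MCF7 cells (Homo sapiens) for inhibition, read by sulforhodamine B assay, with a stated time of 48 h; a higher number here means a weaker inhibitor of growth, a lower number a stronger inhibitor of growth. Within the data shown here, compound 2 gives the lowest of the three numbers, but compound 1 and compound 3 both lie within the scatter of it, so the three values cannot be told apart and no compound can be called the strongest or weakest on these data alone. Among the measured compounds shown here, no pair of measured compounds differs in a single place, so no measured step is available.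

Compound 4 `N=C(N)c1ccc(-c2ccc(-c3ccccc3)s2)cc1F` is the next compound and has not been measured in this assay. Its relation to compound 2 is hydrogen in place of chloro on an aromatic carbon. The chloro that leaves sits on an aromatic carbon of a six-membered aromatic ring of carbon only, para to a large group. For the measured compounds named here, nothing among the measured compounds shows what removing a chloro at this place does, since the differences between compound 1, compound 2 and compound 3 involve other groups and are all within the scatter. The expectation for the step from compound 2 to compound 4 in this assay is therefore a small one, a 1.5-fold higher number from compound 2 to compound 4 (0.19 log units; within the scatter), leaning toward a higher number but not clearly beyond the scatter. Compound 4 is expected to give about 260 nM in this assay, with a plausible range from 120 nM to 600 nM.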

Compound 4, concentration for 50% growth inhibition: 3170 nM
Compound 4: the middle estimate sits 12-fold (1.09 log units) below what was measured; measured number above the stated range.
By their numbers in this assay, from the lowest: compounds 2, 1 and 3 (each within the scatter of the next); then compound 4.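

In this assay, the change from 4-chlorophenyl to phenyl gives a 19-fold higher number from compound 2 to compound 4 (1.28 log units; beyond the scatter), so loss of the chloro on this aromatic carbon, para to a large group, sharply weakens growth inhibition. The earlier compounds shown here, whose values all lie within the scatter of one another, gave no sign that the series could be this sensitive to a single-atom change at this place. Nothing measured here accounts for the size of this step.

Still open, on these data alone, is whether chloro itself is required: a bromo, a methyl or a trifluoromethyl in its place would show whether another group can return compound 4 to the level of compound 2. As far as these compounds go, it is also open whether the same step holds in a matched pair without the fluoro shared by compound 2 and compound 4.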